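The compounds below may be only part of what the source reports. "The series", "measured", "known", "first", "only" and "open" are said of these compounds alone.

Working notes on the series. The shared core is that of compound 1 `COc1ccc2c(c1)c(/C=N\NC(=O)c1c[nH]c3ccc(Br)cc13)cn2Cc1ccc(Cl)cc1`. In a functional assay on LNCaP cells (Homo sapiens) for cytotoxicity (on this read-out lower numbers stand for stronger inhibition and higher numbers for weaker inhibition), compound 1 gives only > 100000 nM, which is a limit of the assay and not a number. Where compound 1 stands on the scale is therefore known only as a limit: the limit of > 100000 nM in this assay, at which 1 of the 3 values shown sits. Compound 2 `O=C(N/N=C\c1cn(Cc2ccc(Cl)cc2)c2ccc(Br)cc12)c1c[nH]c2ccccc12` gives 3700 nM in this assay. Compound 3 `O=C(N/N=C\c1cn(Cc2ccc(Cl)cc2)c2cc(F)ccc12)c1c[nH]c2ccccc12` gives 55200 nM in this assay. Both compound 2 and compound 3 carry the unsubstituted indole carboxamide and return numbers rather than a limit. Compound 4 `COc1ccc2c(c1)c(/C=N\NC(=O)c1c[nH]c3ccccc13)cn2Cc1ccc(Cl)cc1` is not yet measured. From compound 1 to compound 4 the change is hydrogen in place of bromo on an aromatic carbon. Compound 4 shares the unsubstituted indole carboxamide of compound 2 and compound 3. The step is expected to run toward stronger inhibition, roughly an at least 2.5-fold lower number from compound 1 to compound 4 (0.39 log units; beyond the scatter), with a wide range given that the starting point is a limit. Compound 4 is estimated at 40000 nM in this assay, expected to fall between 8000 nM and 200000 nM.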

Compound 4, half-maximal inhibitory concentration: > 100000 nM
Compound 4: a limit, no number (the forecaster's own chance of this, stated with the estimate: 30%); middle value at least 2.5-fold (0.39 log units) from the limit.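

Hydrogen in place of bromo on the 5-bromo-1H-indol-3-yl group leaves compound 4 at a limit of the assay in this assay, as compound 1 is, so that step cannot be read. The readable change is methoxy in place of bromo on an aromatic carbon of the shared core, which gives an at least 27-fold higher number from compound 2 to compound 4 (1.43 log units; beyond the scatter), so the unsubstituted indole carboxamide alone does not bring a measured number. With methoxy on the core, both the bromo and the hydrogen forms of the carboxamide indole end at the same limit: the limit of > 100000 nM in this assay, at which 2 of the 4 values shown sit.

Going by these compounds alone, no pair with a number on both sides shows what bromo on the carboxamide indole does. Also open, as far as these compounds go, is what an amine or a carboxylic acid in place of methoxy on that aromatic carbon would give.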